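Chloro added to the hydroxymethyl-bearing ring of compound 2

The source may hold more compounds than are shown below. What is called first, only, known or untested is meant among the compounds shown, and "the series" means these compounds.

Among the measured compounds shown here, compound 2 `O=S(=O)(Nc1cccc(CO)c1)c1ccc(-c2ccc(Br)cc2)cc1` is the only member of this set with a numerical result: in a functional assay on J774 cells (Mus musculus) for cytotoxicity, read by resazurin assay, with a stated time of 72 h (a higher number here means a weaker inhibitor, a lower number a stronger inhibitor), compound 2 gives 2500 nM. Compound 1 `O=S(=O)(Nc1cccc(CO)c1O)c1ccc(-c2ccc(Br)cc2)cc1` reaches only the limit of the assay, giving > 5000 nM. Compound 3 `CN(C)c1ccc(-c2ccc(S(=O)(=O)Nc3cccc(CO)c3)cc2)cc1` likewise returns only a limit, > 5000 nM. The step of an at least 2.0-fold lower number from compound 1 to compound 2 (0.30 log units; that floor lies within the scatter) and the step of an at least 2.0-fold higher number from compound 2 to compound 3 (0.30 log units; that floor lies within the scatter) are thus known only as floors, reflecting (the limit of > 5000 nM in this assay, at which 2 of the 3 values shown sit). Compound 4 `O=S(=O)(Nc1ccc(Cl)c(CO)c1)c1ccc(-c2ccc(Br)cc2)cc1` differs from compound 2 by chloro in place of hydrogen on an aromatic carbon, sitting ortho to a hydroxymethyl group and para to a large group. Neither measured step touches this position, so no step beyond the scatter is expected in this assay. Compound 4 is therefore estimated at 2500 nM, between 1000 nM and 6000 nM, an expected step of no change at the digits printed from compound 2 to compound 4 (within the scatter).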

Compound 4, half-maximal inhibitory concentration: > 5000 nM
Compound 4: no number, only a limit (the forecaster's own chance of this, stated with the estimate: 30%); at least 2.0-fold (0.30 log units) between middle value and limit.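

Chloro in place of hydrogen on this aromatic carbon, ortho to a hydroxymethyl group, gives an at least 2.0-fold higher number from compound 2 to compound 4 (0.30 log units; that floor lies within the scatter) in this assay, the first reading at a position that the earlier compounds left untouched. Compound 4 gives > 5000 nM, which is a limit and not a number. The step is therefore only a floor within the scatter, so the true effect of chloro here cannot be sized: the limit of > 5000 nM in this assay, at which 3 of the 4 values shown sit.

Still open, as far as these compounds go, is whether fluoro, a methyl group or an amine on this same carbon would give a number rather than a limit in this assay.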